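Halogen swap on the aryl hydrazone of two different cores

The source may report more compounds than this note shows. Statements on the series, on what has been measured and on what is new or still open speak of the compounds shown alone.

Measured compounds:
Compound 1, `O=C(N/N=C\c1ccc(Cl)cc1)C1=C(Cl)c2ccccc2CCC1`, 140 nM
Compound 2, `O=C(N/N=C\c1ccc(F)cc1)C1=C(Cl)c2ccccc2CCC1`, 270 nM
Compound 3, `Cc1cc2c(cc1C)C(Cl)=C(C(=O)N/N=C\c1ccc(Cl)cc1)CCC2`, 18300 nM

In a functional assay on IMR-32 cells (Homo sapiens) for inhibition, read by sulforhodamine B assay, with a stated time of 48 h (a higher number here means a weaker inhibitor of growth, a lower number a stronger inhibitor of growth), compound 1 gives 140 nM and compound 2 gives 270 nM. The change between them is fluoro in place of chloro on an aromatic carbon, and its step is a 1.9-fold higher number from compound 1 to compound 2 (0.29 log units; within the scatter). Compound 3 gives 18300 nM in this assay; how its core differs from that of compound 1 is not broken down here. Compound 4, `Cc1cc2c(cc1C)C(Cl)=C(C(=O)N/N=C\c1ccc(F)cc1)CCC2`, has not yet been measured. It differs from compound 3 by fluoro in place of chloro on an aromatic carbon, the same change as from compound 1 to compound 2. Since that step was within the scatter, compound 4 is expected to sit close to compound 3 in this assay, with an expected step of a 1.4-fold higher number from compound 3 to compound 4 (0.14 log units; within the scatter), resting on a 1.9-fold higher number from compound 1 to compound 2 (0.29 log units; within the scatter). Compound 4 is estimated at 25000 nM, between 9000 nM and 80000 nM.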

Compound 4, concentration for 50% growth inhibition: 3500 nM
Beside the measured number, compound 4's estimate is 7.1-fold (0.85 log units) above it; the measured number lies below the stated range.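

In this assay, the change from 4-chlorophenyl to 4-fluorophenyl gave a 5.2-fold lower number from compound 3 to compound 4 (0.72 log units; beyond the scatter). Set beside the earlier step on the core of compound 1, this result shows that the size of the step did not carry over from one core to the other: the same change on two cores in this assay, a 1.9-fold higher number (0.29 log units; within the scatter) from compound 1 to compound 2 and a 5.2-fold lower number (0.72 log units; beyond the scatter) from compound 3 to compound 4, 10-fold (1.00 log units) apart, beyond the scatter of two such steps. For the compounds shown here, with only one pair on each core, it does not show why the steps differ, or how the change would behave on any further core.

The compounds shown leave open whether another group in place of the halogen, such as methoxy or an amine, would follow either step. They also leave open which feature of the core of compound 3 sets its step apart.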